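Ethyl in place of hydrogen: plasma protein binding notes

The compounds below may be only part of what the source reports. "The series", "measured", "known", "first", "only" and "open" are said of these compounds alone.

- compound 1 `O=C(O)CCc1cc(F)c(OCc2c(-c3ccc(Cl)cc3)noc2C(F)(F)F)c(F)c1`: 99.8%
- compound 2 `O=C(O)CCc1cc(F)c(OCc2c(-c3ccccc3)noc2C(F)(F)F)c(F)c1`: 98.8%

In an ADME assay on a cell-free system (plasma, Rattus norvegicus) for protein binding, compound 2 (98.8%) holds the higher unbound fraction of the two measured compounds. Compound 3 `CCc1ccc(-c2noc(C(F)(F)F)c2COc2c(F)cc(CCC(=O)O)cc2F)cc1` carries ethyl in place of hydrogen on an aromatic carbon . Among the compounds with values here, one measured step bears on this, hydrogen in place of chloro on an aromatic carbon: a 6.0-fold higher unbound fraction from compound 1 to compound 2 (0.78 log units; beyond the scatter). Read in reverse, it shows a group replacing hydrogen with less compound left free, but no ethyl example has been measured. A similar or somewhat smaller step in the same direction, beyond the scatter, is therefore expected: an estimated a 3.0-fold lower unbound fraction from compound 2 to compound 3 (0.48 log units; beyond the scatter). The expected value for compound 3 is 99.6% (range 99% to 99.9%) .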

Compound 3, plasma protein binding: 99.9%
The estimate for compound 3 lay 4.0-fold (0.60 log units) (unbound fraction) above the measured number; low and high end bracket the measured number.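

In this assay, ethyl in place of hydrogen on this aromatic carbon gives a 12-fold lower unbound fraction from compound 2 to compound 3 (1.08 log units; beyond the scatter), so the position also responds to a group other than chloro. Ethyl and chloro are not separated here, with a 2.0-fold lower unbound fraction from compound 1 to compound 3 (0.30 log units; within the scatter), which leaves compound 2, with hydrogen, apart from both substituted compounds. Nothing available accounts for the size of these steps.

Open, as far as these compounds go, is whether a longer chain such as propyl, or a methoxy group or an amine, on this carbon would leave as little compound free. From the compounds shown here alone, whether any group here can match or exceed the unbound fraction of compound 2 also remains open.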